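The source may hold more compounds than are shown below. What is called first, only, known or untested is meant among the compounds shown, and "the series" means these compounds.

Measured in an ADME assay for pharmacokinetics, read by LC-MS, in phosphate buffer, with a stated time of 120 min, at pH 7.4, tested at 1 uM, in the presence of a further agent that is not named here; a lower number here means that the compound disappears faster, a higher number that the compound lasts longer:
- Compound 1 `C=C(C(=O)Nc1ccccc1)C(F)(F)F`: 0.25 h
- Compound 2 `CN(C)CC/C=C/C(=O)Nc1ccccc1`: 7.38 h
- Compound 3 `COC(=O)CN(C)C/C=C/C(=O)Nc1ccccc1`: > 8.53 h (a limit, not a number)

Compound 1 has the lowest number of the three. Compound 2, at 7.38 h, lies far beyond the usual scatter above it. Compound 4 `C=C(COC)C(=O)Nc1ccccc1` carries methoxymethyl in place of trifluoromethyl on a double-bonded chain carbon bound to a carbonyl carbon. Among the compounds with values here, no two measured compounds differ in just one place, so no measured step can serve as a guide. In this assay, a rise beyond the scatter is expected: a 10-fold higher number from compound 1 to compound 4 (1.00 log units; beyond the scatter). This expectation rests on the low position of compound 1 at 0.25 h. For compound 4 the estimated half-life is 2.5 h, with an expected range from 0.6 h to 9 h.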

Compound 4, half-life: 4.02 h
For compound 4 the middle estimate is 1.6-fold (0.21 log units) below the measured one; measured number inside the range.
By their numbers in this assay, from the lowest: compound 1; then compounds 4 and 2 (each within the scatter of the next). At a limit, above all of these: compound 3.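

In this assay, the double-bonded chain carbon bound to a carbonyl carbon proves to be a place where a single change matters: methoxymethyl in place of trifluoromethyl gives a 16-fold higher number from compound 1 to compound 4 (1.21 log units; beyond the scatter). The earlier compounds shown here offered no such comparison in one place. Nothing shown here accounts for the size of this step. On these data alone, what an amine or a longer chain would do at this same place remains open. So does whether the same swap would give a similar step on another core.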